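The source may report more compounds than this note shows. Statements on the series, on what has been measured and on what is new or still open speak of the compounds shown alone.

Compound 1 `CNc1nccc(N2CC[C@H](NC(=O)Nc3ccc(OC(F)(F)F)cc3)C2)n1` is the aryl urea carrying the shared core; in an assay on a protein complex for displacement of a labelled ligand from CDK8/Cyclin C (Homo sapiens), read by TR-FRET, with a stated time of 1 h (a higher number here means a weaker inhibitor, a lower number a stronger inhibitor), compound 1 gives 44.1 nM, the higher of the two numbers recorded so far. Within the data shown here, compound 2 `O=C(Nc1ccc(Cl)c(C(F)(F)F)c1)N[C@H]1CCN(c2ccc3nncn3n2)C1`, on a different core, gives 4.2 nM in this assay, a gap beyond the usual scatter; no single-point step links the two.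

Compound 3 `CNc1nccc(N2CC[C@H](NC(=O)Nc3ccc(OC)cc3)C2)n1` differs from compound 1 in one place: methyl in place of trifluoromethyl on an oxygen on an aromatic ring. Among the measured compounds shown here, no measured step of this kind exists in the set, so the direction rests on expectation alone. A modest rise, beyond the scatter but small, is expected: a 2.3-fold higher number from compound 1 to compound 3 (0.36 log units; beyond the scatter). Compound 3 is accordingly estimated at 100 nM in this assay, within 35 nM to 300 nM.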

Compound 3, half-maximal inhibitory concentration in the CDK8/Cyclin C assay: 7160 nM
Estimate against measurement, compound 3: 72-fold (1.85 log units) below; measured number outside the range, above it.
By their numbers in the CDK8/Cyclin C assay, from the lowest: compound 2; then compound 1; then compound 3.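

Trifluoromethyl on this oxygen is decisive on the shared core: in the CDK8/Cyclin C assay methyl in its place gives a 160-fold higher number from compound 1 to compound 3 (2.21 log units; beyond the scatter) and leaves little of the activity. In a physicochemical assay for solubility, measured as kinetic solubility (on this read-out higher numbers stand for higher solubility and lower numbers for lower solubility), compound 1 gives 70400 nM and compound 3 gives 92600 nM with the two within the usual scatter, so the swap gains nothing on that read-out.

On these data alone, whether ethoxy, difluoromethoxy, or a chlorine in place of the whole trifluoromethoxy would hold the number of compound 1 stays open. Nothing shown gives a cause for the size of this step.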